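Fluoro for Hydroxy in a Series Sitting at the Limit

The source may hold more compounds than are shown below. What is called first, only, known or untested is meant among the compounds shown, and "the series" means these compounds.

Compound 1, `COc1nc(=O)n(C)c(CC(F)(COC(C)=O)COC(C)=O)c1C`: in an ADME assay on WI-38 cells (Homo sapiens) for antiproliferative activity, read by MTT assay, with a stated time of 72 h (on this read-out higher numbers stand for weaker inhibition and lower numbers for stronger inhibition), compound 1 gives > 100000 nM, which is a limit of the assay and not a number.
Compound 2, `COc1nc(=O)n(C)c(CC(O)(COC(C)=O)COC(C)=O)c1C`: in this assay compound 2 gives > 100000 nM, again a limit of the assay.
Compound 3, `CC(=O)OCC(O)(COC(C)=O)Cc1c(C)c(=O)[nH]c(=O)n1C`: in this assay compound 3 gives > 100000 nM, also a limit of the assay.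

Compounds 1 and 2 share one core, and compound 1 arises from compound 2 by fluoro in place of hydroxy on a saturated chain carbon bound to three saturated chain carbons. Because (the limit of > 100000 nM in this assay, at which 3 of the 3 values shown sit), the step that the two limits leave unreadable from compound 2 to compound 1 cannot be sized in either direction. Compound 3 carries a different core; how the core of compound 3 differs from the core of compound 2 is not broken down here.

Compound 4, `CC(=O)OCC(F)(COC(C)=O)Cc1c(C)c(=O)[nH]c(=O)n1C`, is not yet measured. It arises from compound 3 by fluoro in place of hydroxy on a saturated chain carbon bound to three saturated chain carbons, the same change as that made from compound 2 to compound 1, at the same place.

For compound 4 in this assay the expected step is a number no higher from compound 3 to compound 4 (the limit leaves the size open). This expectation rests on compound 3, whose value > 100000 nM is a limit, and on (the limit of > 100000 nM in this assay, at which 3 of the 3 values shown sit), so that no readable movement is anticipated from the change. Compound 4 is therefore estimated at 100000 nM, with a range of 40000 nM to 300000 nM, and most likely the assay will again report only a limit.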

Compound 4, half-maximal inhibitory concentration: > 100000 nM
Compound 4 gave a limit, no number; the forecaster's own chance of this, stated with the estimate: 90%; the middle value sits exactly at the limit.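

No step can be read from compound 3 to compound 4, because in this assay both compounds stand at a limit of the assay and not at a number: the limit of > 100000 nM in this assay, at which 4 of the 4 values shown sit.

The compounds shown leave open whether fluoro in place of hydroxy moves the read-out in this assay on either core, and what number any of the four compounds would give.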